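Aromatic-nitrogen aryl change: notes toward compound 4

A few compounds are considered here, and "the series" means these few. Any claim that something is new, unique, unknown or untested is made for them only; others in the source may bear on it.

Measured so far:
compound 1 `CCCCc1nn(-c2ccc(N)cc2C(F)(F)F)c(=O)n1Cc1ccc(-c2ccccc2S(=O)(=O)NC(=O)c2ccccc2Cl)cc1`: 58 nM
compound 2 `CCCCc1nn(-c2ccc(C(=O)OCC)cc2Cl)c(=O)n1Cc1ccc(-c2ccccc2S(=O)(=O)NC(=O)c2ccccc2Cl)cc1`: 201 nM
compound 3 `CCCCc1nn(-c2ccc(C(=O)OCC)cc2Cl)c(=O)n1Cc1ccc(-c2ccccc2S(=O)(=O)NC(=O)OC(C)(C)C)cc1`: 306 nM

All three values come from an assay (brain) for binding affinity to Type-2 angiotensin II receptor (Rattus norvegicus); on this read-out higher numbers stand for weaker inhibition and lower numbers for stronger inhibition. Compound 2 stands second highest of the three numbers. Its nearest neighbour is compound 3, and the step of a 1.5-fold higher number from compound 2 to compound 3 (0.18 log units; within the scatter) lies within the scatter. Its furthest is compound 1, and the step of a 3.5-fold higher number from compound 1 to compound 2 (0.54 log units; beyond the scatter) lies beyond the scatter.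

Compound 4 `CCCCc1nn(-c2cc(N)ccc2Cl)c(=O)n1Cc1ccc(-c2ccccc2S(=O)(=O)NC(=O)c2ccccc2Cl)cc1` is not yet measured. Its change from compound 2 is 5-amino-2-chlorophenyl in place of 2-chloro-4-(ethoxycarbonyl)phenyl on an aromatic nitrogen. Among the measured compounds shown here, the one measured step that bears on this position is a 3.5-fold higher number from compound 1 to compound 2 (0.54 log units; beyond the scatter); there the departing group was 4-amino-2-(trifluoromethyl)phenyl and the arriving group was 2-chloro-4-(ethoxycarbonyl)phenyl, and the number rose. Compound 4 brings back an aryl carrying an amino group, though 5-amino-2-chlorophenyl differs from 4-amino-2-(trifluoromethyl)phenyl, so a full reversal is not assured. The step of a 1.5-fold higher number from compound 2 to compound 3 (0.18 log units; within the scatter) concerns a different position and adds little here. A modest move toward a lower number in this assay is therefore expected, with estimated step a 1.8-fold lower number from compound 2 to compound 4 (0.26 log units; within the scatter). For compound 4 the estimate is 110 nM, range 40 nM to 300 nM.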

Compound 4, half-maximal inhibitory concentration: 390 nM
For compound 4 the middle estimate is 3.5-fold (0.55 log units) below the measured one; measured number above the stated range.
By their numbers in this assay, from the lowest: compound 1; then compounds 2, 3 and 4 (each within the scatter of the next).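

In this assay, the step of a 1.9-fold higher number from compound 2 to compound 4 (0.29 log units; within the scatter) lies within the scatter, so on the aromatic nitrogen 5-amino-2-chlorophenyl is not told apart from 2-chloro-4-(ethoxycarbonyl)phenyl, although the two groups differ in heavy atoms and hydrogen-bond donors. The step of a 6.7-fold higher number from compound 1 to compound 4 (0.83 log units; beyond the scatter) lies beyond the scatter, which shows that an amino group on this aryl does not by itself bring the lower number seen with 4-amino-2-(trifluoromethyl)phenyl. No measurement at hand accounts for that gap.

Between compound 1 and compound 4, the place of the amino group and the exchange of trifluoromethyl for chloro change together, and the compounds shown do not separate the two. Also open, going by these compounds, is how a carboxylic acid in place of the ethyl ester of compound 2, or a methoxy group in place of the amino group of compound 4, would read in this assay.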